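Thiophen-2-yl to 1-Benzofuran-2-yl on Two Related Cores

This account rests on a few compounds, and the source may have more. Where it says the series, first, only, none or still open, it means among the compounds named here.

Compound 1 `O=c1[nH]cnc2c1c(-c1cccs1)cn2[C@@H]1O[C@H](CO)[C@@H](O)[C@H]1O` and compound 2 `O=c1[nH]cnc2c1c(-c1cc3ccccc3o1)cn2[C@@H]1O[C@H](CO)[C@@H](O)[C@H]1O` share one core and differ at a single aromatic carbon, where (1-benzofuran-2-yl in place of thiophen-2-yl on an aromatic carbon). Compound 3 `CN(C)c1ncnc2c1c(-c1cccs1)cn2[C@@H]1O[C@H](CO)[C@@H](O)[C@H]1O` carries the same thiophen-2-yl group on a second core; the difference between the two cores is not broken down here. Compound 4 `CN(C)c1ncnc2c1c(-c1cc3ccccc3o1)cn2[C@@H]1O[C@H](CO)[C@@H](O)[C@H]1O`, which has not yet been measured, joins that second core to the larger group, and the change from compound 3 to compound 4 is the same one seen between compound 1 and compound 2: 1-benzofuran-2-yl in place of thiophen-2-yl on an aromatic carbon.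

In an ADME assay on MRC5 cells (Homo sapiens), read by MTT assay, with a stated time of 72 h (on this read-out higher numbers stand for weaker inhibition and lower numbers for stronger inhibition), compound 1 gives > 100000 nM, which is a limit of the assay and not a number. In this assay compound 2 gives > 100000 nM, also a limit. In this assay compound 3 gives > 100000 nM, again a limit. Because both ends sit at the limit of > 100000 nM in this assay, at which 3 of the 3 values shown sit, the step that the two limits leave unreadable from compound 1 to compound 2 cannot be read, and nothing in the data says whether the exchange moves the read-out at all.

Among the measured compounds shown here, since the same exchange on the first core left both compounds at the limit, and compound 3 sits there as well with > 100000 nM, compound 4 is expected to do the same, with an estimated 150000 nM in this assay. The expected step that the limit leaves unreadable from compound 3 to compound 4 is therefore estimated to stay unreadable, most likely reported only as a limit.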

Compound 4, half-maximal inhibitory concentration: > 100000 nM
Compound 4: no number, only a limit; the forecaster's own chance of this, stated with the estimate: 85%; the middle value lies beyond the limit too.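

In this assay compound 4 gives > 100000 nM, a limit of the assay and not a number. No step from compound 3 to compound 4 can be read, because both compounds sit at the same limit: the limit of > 100000 nM in this assay, at which 4 of the 4 values shown sit.

The compounds shown leave open whether 1-benzofuran-2-yl in place of thiophen-2-yl moves the read-out at all on either core, and how the four compounds rank against one another.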